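This account rests on a few compounds, and the source may have more. Where it says the series, first, only, none or still open, it means among the compounds named here.

Working notes on the series. Compound 1 `C=C(CC)C(=O)c1ccc(OCC(=O)Nc2ccc(C(=O)O)cn2)c(Cl)c1Cl` and compound 2 `C=C(CC)C(=O)c1ccc(OCC(=O)Nc2ccc(O)c([N+](=O)[O-])c2)c(Cl)c1Cl` share one core and differ only in the group carried on the amide-type nitrogen. In a functional assay on CLL cells (Homo sapiens) for cytotoxicity, read by MTT assay, with a stated time of 48 h (a lower number here means that less compound is needed, a higher number that more compound is needed for the effect), compound 1 gives 14900 nM. Compound 2 gives 7400 nM in this assay. Compound 1 thus holds the highest of the two numbers recorded so far, but its gap to compound 2 stays within the scatter, so no order between the two can be drawn. Compound 3 `C=C(CC)C(=O)c1ccc(OCC(=O)NCCO)c(Cl)c1Cl` has not yet been measured in this assay. Against compound 1 it shows (2-hydroxyethyl in place of 5-carboxypyridin-2-yl on an amide-type nitrogen). Among the measured compounds shown here, no measured step between compounds is available, and the two measured compounds give no sign that this part of the molecule moves the number beyond the scatter. Expected here: a 1.3-fold higher number from compound 1 to compound 3 (0.13 log units; within the scatter), at most a small move toward a higher number, or none beyond the scatter. Compound 3 is therefore estimated at 20000 nM, with a range from 8000 nM to 50000 nM.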

Compound 3, half-maximal effective concentration: > 25000 nM
Compound 3: only a limit was reported; the forecaster's own chance of this, stated with the estimate: 15%; middle value at least 1.2-fold (0.09 log units) from the limit.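

Compound 3 gives > 25000 nM in this assay, and this value is a limit and not a number. Putting 2-hydroxyethyl in place of 5-carboxypyridin-2-yl on the amide-type nitrogen gives an at least 1.6-fold higher number from compound 1 to compound 3 (0.22 log units; that floor lies within the scatter), so the step has a floor but no measured size. This is the first change at this position that removes the six-membered aromatic ring, and it brings no lower number, which is all that can be read from the result: the limit of > 25000 nM in this assay, at which 1 of the 3 values shown sits.

As far as these compounds go, whether the step from compound 1 to compound 3 really exceeds the scatter stays open, as does where compound 3 would fall if measured as a number. Also open, from the compounds shown here alone, is whether a longer chain ending in a carboxylic acid, or an amine, on this nitrogen would give a lower number in this assay.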